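Removing the aryl triazole from the oxime ether

The compounds below may be only part of what the source reports. "The series", "measured", "known", "first", "only" and "open" are said of these compounds alone.

- compound 1 `COc1ccc([C@@H]2C/C(=N/OCc3cn(-c4ccc(O)cc4)nn3)c3cc(CC=C(C)C)c(OC)cc3O2)cc1` gives 65%
- compound 2 `COc1ccc([C@@H]2C/C(=N/OCc3cn(-c4cccc(CO)c4)nn3)c3cc(CC=C(C)C)c(OC)cc3O2)cc1` gives 27%
- compound 3 `COc1ccc([C@@H]2C/C(=N/OCc3cn(-c4ccc(NC(C)=O)cc4)nn3)c3cc(CC=C(C)C)c(OC)cc3O2)cc1` gives 6%

In a functional assay on HCT-116 cells (Homo sapiens) for inhibition, read by sulforhodamine B assay, with a stated time of 48 h, tested at 50 uM (a lower number here means less inhibition of growth, a higher number more inhibition of growth at the concentration tested), compound 1 stands highest of the three measured compounds. Compound 4 `C#CCO/N=C1/C[C@@H](c2ccc(OC)cc2)Oc2cc(OC)c(CC=C(C)C)cc21` has not yet been measured. Its difference from compound 1 is ethynyl in place of 1-(4-hydroxyphenyl)-1H-1,2,3-triazol-4-yl on a saturated chain carbon bound to an oxygen.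

For the measured compounds named here, no measured step removes this whole group. The nearest evidence comes from changes on its aromatic part: a number 38 percentage points lower from compound 1 to compound 2 (beyond the scatter) and a number 59 percentage points lower from compound 1 to compound 3 (beyond the scatter), both large and both downward. The step of a number 21 percentage points lower from compound 2 to compound 3 (beyond the scatter) is modest and shows that the read-out also varies among the altered compounds. All three compounds keep the triazole, so the data do not show what its loss does. A large downward step in this assay is expected, with wide uncertainty. The expected change is a number 40 percentage points lower from compound 1 to compound 4 (beyond the scatter). For compound 4 the estimated value is 25%, with an expected range of 5% to 55%.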

Compound 4, percent growth inhibition at one concentration: 65%
The estimate for compound 4 lay 40 percentage points below the measured number, outside the stated range (above it).
By their numbers in this assay, from the lowest: compound 3; then compound 2; then compounds 1 and 4 (each within the scatter of the next).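

In this assay, ethynyl in place of 1-(4-hydroxyphenyl)-1H-1,2,3-triazol-4-yl on a saturated chain carbon bound to an oxygen gives no change at the digits printed from compound 1 to compound 4 (within the scatter). For the compounds shown here, the aryl triazole is therefore not required for growth inhibition in this read-out at the concentration tested, which the earlier compounds, all of which keep it, could not show. No measurement here explains why the read-out holds when the aryl triazole leaves.

A single concentration leaves open whether compound 1 and compound 4 would also stay level at lower concentrations. Also open, as far as these compounds go, is how this position responds to other ends on the same chain, such as an unsubstituted triazole, a primary amine, a carboxylic acid or a longer alkyl chain in place of ethynyl.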